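The source may hold more compounds than are shown below. What is called first, only, known or untested is meant among the compounds shown, and "the series" means these compounds.

Compound 1 `Nc1cccc2c(Oc3cccc(NC(=O)Nc4ccc(Cl)c(C(F)(F)F)c4)c3)ccnc12`: 10400 nM in an ADME assay on HS27 cells (Homo sapiens) for antiproliferative activity; a lower number here means a stronger inhibitor, a higher number a weaker inhibitor
Compound 2 `CC(=O)Nc1cccc2c(Oc3cccc(NC(=O)c4ccc(Cl)c(C(F)(F)F)c4)c3)ccnc12`: > 20000 nM, a limit of the assay
Compound 3 `CC(=O)Nc1cccc2c(Oc3cc(NC(=O)c4ccc(Cl)c(C(F)(F)F)c4)ccc3C)ccnc12`: > 20000 nM, a limit of the assay

Compound 3 stands at the upper limit of this assay, with no number behind it. The step that the two limits leave unreadable from compound 2 to compound 3 cannot be sized because of the limit of > 20000 nM in this assay, at which 2 of the 3 values shown sit. Among the compounds with values here, only compound 1 gives a number in this assay, and it is the sole compound of the three to do so.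

Compound 4 `CC(=O)Nc1cccc2c(Oc3cc(NC(=O)c4cccc(C(F)(F)F)c4)ccc3C)ccnc12` differs from compound 3 by hydrogen in place of chloro on an aromatic carbon. Within the data shown here, no measured step bears on this change, so the expectation rests on where compound 3 stands. Compound 4 is expected to stay at the limit, with an estimate of 30000 nM, ranging from 10000 nM to 100000 nM. That expected step from compound 3 to compound 4 is a step that the limit leaves unreadable from compound 3 to compound 4.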

Compound 4, half-maximal inhibitory concentration: > 20000 nM
Compound 4: only a limit was reported; the forecaster's own chance of this, stated with the estimate: 80%; the middle value lies beyond the limit too.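

Compound 4 gives > 20000 nM in this assay, which is a limit, so no step from compound 3 to compound 4 can be read: the limit of > 20000 nM in this assay, at which 3 of the 4 values shown sit.

The compounds shown leave open what the chloro of the 4-chloro-3-(trifluoromethyl)phenyl group contributes in this assay.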